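The source may hold more compounds than are shown below. What is called first, only, known or untested is meant among the compounds shown, and "the series" means these compounds.

Compound 1, with the structure `CSc1ccccc1Nc1nc2c(Nc3ccc(C(F)(F)F)cc3)ncnc2s1`, is the reference point of this small set. In a functional assay on HEK293 cells for antagonist activity at transient receptor potential cation channel subfamily V member 1 (Rattus norvegicus), read by calcium flux (on this read-out higher numbers stand for weaker inhibition and lower numbers for stronger inhibition), compound 1 gives 26 nM. Compound 2, with the structure `CS(=O)(=O)c1ccccc1Nc1nc2c(Nc3ccc(C(F)(F)F)cc3)ncnc2s1`, differs from compound 1 by a single change, (methylsulfonyl in place of methylsulfanyl on an aromatic carbon), and in this assay compound 2 gives 221 nM. The step of an 8.5-fold higher number from compound 1 to compound 2 (0.93 log units; beyond the scatter) therefore goes in the direction of weaker inhibition.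

Compound 3, with the structure `CSc1ccc(Nc2ncnc3sc(Nc4c(Cl)cccc4Cl)nc23)cc1`, carries a different core, and the difference between the two cores is not broken down here. In this assay compound 3 gives 12 nM, which is the lowest number of the three measured compounds, with compound 1 nearest to it and compound 2 furthest away.

Compound 4, with the structure `CS(=O)(=O)c1ccc(Nc2ncnc3sc(Nc4c(Cl)cccc4Cl)nc23)cc1`, is not yet measured. It differs from compound 3 by methylsulfonyl in place of methylsulfanyl on an aromatic carbon. Going by the values given here, this is the same kind of change as the one from compound 1 to compound 2, not the same change: in compound 1 the place is ortho to a large group, while in compound 3 it is para to a large group, and the cores of the two pairs differ.

Because the step of an 8.5-fold higher number from compound 1 to compound 2 (0.93 log units; beyond the scatter) was a modest loss, the change from compound 3 to compound 4 is expected to produce a step of similar size, an 8.3-fold higher number from compound 3 to compound 4 (0.92 log units; beyond the scatter), in this assay. On that basis compound 4 is estimated to give 100 nM, with a range expected from 30 nM to 350 nM.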

Compound 4, half-maximal inhibitory concentration: 3 nM
For compound 4 the middle estimate is 33-fold (1.52 log units) above the measured one, outside the stated range (below it).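

In this assay, methylsulfonyl in place of methylsulfanyl gave a 4.0-fold lower number from compound 3 to compound 4 (0.60 log units; beyond the scatter), a move toward stronger inhibition, so this change did not keep its direction from one pair of compounds to the other: the same change on two cores in this assay, an 8.5-fold higher number (0.93 log units; beyond the scatter) from compound 1 to compound 2 and a 4.0-fold lower number (0.60 log units; beyond the scatter) from compound 3 to compound 4, 34-fold (1.53 log units) apart, beyond the scatter of two such steps. Within this series, then, the effect of the change on one core could not be carried over to the other core, not even as to whether inhibition grew stronger or weaker. What the result does not show is which difference between the two pairs goes with the reversal, for they differ both in the core and in where the group sits, and two pairs cannot separate these or give a cause.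

The compounds shown leave open what this change does on the core of compound 1 when the group is para to a large group, and what it does on the core of compound 3 when the group sits where it does in compound 1. They also leave open how other groups at the place held by methylsulfonyl in compound 4, such as a carboxylic acid, an amine or a longer chain, would behave in this assay.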